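The source may hold more compounds than are shown below. What is called first, only, known or untested is meant among the compounds shown, and "the series" means these compounds.

Measured so far in a functional assay on HepG2 cells (Homo sapiens) for antiproliferative activity, read by MTT assay, with a stated time of 24 h; a lower number here means a stronger inhibitor, a higher number a weaker inhibitor:
compound 1 `Clc1ccc(C2CC(c3ccccc3)=NN2c2ccc(-c3ccccc3)nn2)cc1` gives 6310 nM;
compound 2 `COc1ccc(C2=NN(c3ccc(-c4ccccc4)nn3)C(c3ccc(Cl)cc3)C2)cc1` gives > 100000 nM, a limit of the assay;
compound 3 `COc1ccc(C2=NN(c3ccc(-c4ccccc4)nn3)C(c3ccc(OC)cc3)C2)cc1` gives > 100000 nM, also a limit.

The step from compound 1 to compound 2 is methoxy in place of hydrogen on an aromatic carbon, and it reads an at least 15-fold higher number from compound 1 to compound 2 (1.19 log units; beyond the scatter); the size rests on (the limit of > 100000 nM in this assay, at which 2 of the 3 values shown sit). The step from compound 2 to compound 3 is a step that the two limits leave unreadable from compound 2 to compound 3. The difference between the cores of compound 1 and compound 3 is not broken down here.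

Compound 4 `COc1ccc(C2=NN(c3ccc(-c4ccccc4)nn3)C(c3ccc(OC)cc3OC)C2)cc1` is not yet measured. Its change from compound 3 is methoxy in place of hydrogen on an aromatic carbon, the same kind of change as from compound 1 to compound 2, but the place differs: para to a large group there, here ortho to a large group and meta to a methoxy group. Given that compound 3 sits at a limit > 100000 nM, the expected step is a step that the limit leaves unreadable from compound 3 to compound 4, and compound 4 is estimated at 150000 nM, between 60000 nM and 500000 nM.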

Compound 4, half-maximal inhibitory concentration: > 100000 nM
Compound 4 was reported as a limit; the forecaster's own chance of this, stated with the estimate: 85%; the middle value is on the limit's open side.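

Among the compounds shown here, no step from compound 2 or compound 3 to compound 4 can be read, because all three compounds stand at a limit of the assay: the limit of > 100000 nM in this assay, at which 3 of the 4 values shown sit. The compounds shown leave open whether compound 2, compound 3 and compound 4 differ from one another at all.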